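The source may report more compounds than this note shows. Statements on the series, on what has been measured and on what is new or still open speak of the compounds shown alone.

Of the compounds shown here, three have been measured in an assay on CHO cells for displacement of a labelled ligand from Substance-P receptor (Homo sapiens); on this read-out lower numbers stand for stronger inhibition and higher numbers for weaker inhibition. Compound 1, `COc1ccccc1N1CCN(C(=O)CCc2c(-c3ccc(Cl)cc3)[nH]c3ccccc23)CC1`, gives 31 nM in this assay. Compound 2, `COc1ccccc1N1CCN(C(=O)CCc2c(-c3ccc(Cl)cc3)[nH]c3cc(Cl)cc(Cl)c23)CC1`, which carries two additional chlorines on its fused ring system, gives 570 nM. Compound 3, `Cn1c(-c2ccc(Cl)cc2)c(CCC(=O)N2CCC(O)(Cc3ccccc3)CC2)c2cc(Br)ccc21`, gives 0.22 nM. Compound 3 thus shows the lowest number of the three: its nearest neighbour is compound 1, whose number is well beyond the scatter above it, and compound 2 sits still further away. Compound 3 differs from the other two in several places at once, so no single change can be credited for its position.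

The step now followed leads from compound 3 to compound 4, `Cn1c(-c2ccc(Cl)cc2)c(CCC(=O)N2CCC(O)(Cc3ccccc3)CC2)c2cc(-c3ccccn3)ccc21`. The change is pyridin-2-yl in place of bromo on an aromatic carbon. Among the compounds with values here, no measured pair among the three compounds isolates this kind of exchange, so there is no precedent here to lean on. A bromine gives way to a larger aromatic ring bearing one hydrogen-bond acceptor, on the same carbon of the fused system. The step from compound 3 to compound 4 is expected to be a small loss, a 2.7-fold higher number from compound 3 to compound 4 (0.44 log units; beyond the scatter), though a result within the scatter would not be surprising. Compound 4 is therefore estimated at 0.6 nM, in a range from 0.1 nM to 4 nM.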

Compound 4, half-maximal inhibitory concentration: 1.7 nM
The estimate for compound 4 lay 2.8-fold (0.45 log units) below the measured number; the measured number falls inside the stated range.
By their numbers in this assay, from the lowest: compound 3; then compound 4; then compound 1; then compound 2.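

Within the data shown here, on this aromatic carbon of the fused system, pyridin-2-yl in place of bromo gives a 7.7-fold higher number from compound 3 to compound 4 (0.89 log units; beyond the scatter) in this assay, and this is the first change that can be read on its own. The step is modest, and compound 4 still gives 1.7 nM, so this carbon can carry a six-membered aromatic ring with 6 heavy atoms where a single bromine stood, at a measurable but limited cost in this assay. No measurement here bears on why the number rises with this exchange.

A single exchange at this carbon cannot separate the effect of adding a ring from the effect of the ring nitrogen, and a plain phenyl ring on the same carbon would help to pull those two apart. Pyridin-3-yl and pyridin-4-yl would show whether the place of the nitrogen within the ring matters, while a methyl group or a nitrile would show how small groups compare with bromo here.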